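The source may report more compounds than this note shows. Statements on the series, on what has been measured and on what is new or still open speak of the compounds shown alone.

Measured compounds in an assay on Sf21 cells for inhibition of high affinity nerve growth factor receptor (Homo sapiens), read by HTRF, with a stated time of 30 min, in the presence of a further agent that is not named here; a lower number here means a stronger inhibitor, a higher number a weaker inhibitor:
- compound 1 `CC1(C)c2[nH]nc(NC(=O)c3ccccc3)c2CN1Cc1cccc(C#N)c1` gives 980 nM
- compound 2 `CC1(C)c2[nH]nc(NC(=O)c3ccccc3)c2CN1Cc1cccc(Br)c1` gives 940 nM
- compound 3 `CC1(C)c2[nH]nc(NC(=O)c3ccccc3)c2CN1Cc1cccc(F)c1F` gives 200 nM

Compound 3 holds the lowest number of the three, with a 4.7-fold lower number from compound 2 to compound 3 (0.67 log units; beyond the scatter) and a 4.9-fold lower number from compound 1 to compound 3 (0.69 log units; beyond the scatter) setting it apart from both others, while a 1.0-fold lower number from compound 1 to compound 2 (0.02 log units; within the scatter) leaves compound 1 and compound 2 indistinguishable.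

Compound 4 `Cc1ccc(CN2Cc3c(NC(=O)c4ccccc4)n[nH]c3C2(C)C)cc1F` carries 3-fluoro-4-methylphenyl in place of 2,3-difluorophenyl on a saturated chain carbon bound to an amine nitrogen in a ring. Within the data shown here, the steps that bear on this are the two into compound 3, since both exchanged a 3-substituted phenyl for the 2,3-difluorophenyl and gave modest gains. Compound 4 keeps a fluorine at the 3-position but loses the 2-fluoro and adds a 4-methyl, so part of that gain is expected to be given back: a modest upward step a 2.3-fold higher number from compound 3 to compound 4 (0.35 log units; beyond the scatter) in this assay is estimated, landing compound 4 between compound 3 and the pair of compound 1 and compound 2, at 450 nM (range 200 nM to 1000 nM).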

Compound 4, half-maximal inhibitory concentration: 940 nM
The estimate for compound 4 lay 2.1-fold (0.32 log units) below the measured number; the measured number falls inside the stated range.
By their numbers in this assay, from the lowest: compound 3; then compounds 2, 4 and 1 (each within the scatter of the next).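

In this assay, 3-fluoro-4-methylphenyl in place of 2,3-difluorophenyl gives a 4.7-fold higher number from compound 3 to compound 4 (0.67 log units; beyond the scatter), so the fluorine the two groups share does not by itself keep the lower number. Nothing separates this group from the other two, with no change at the digits printed from compound 2 to compound 4 (within the scatter) and a 1.0-fold lower number from compound 1 to compound 4 (0.02 log units; within the scatter), which leaves compound 3 alone among the four in standing apart at this place. No measured evidence bears on this result.

On these data alone, whether compound 3 needs both fluorines remains open. So does how an unsubstituted benzyl or a pyridylmethyl group would read here.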